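The compounds below may be only part of what the source reports. "The series", "measured", "known", "first", "only" and "open" are said of these compounds alone.

Among the compounds with values here, the three compounds measured so far share one core and differ only in the aryl group carried on the ether oxygen. Compound 1 `COc1ccc(OCCCON2C(N)=NC(N)=NC23CCOCC3)cc1` stands at the weak end: in a functional assay on HL-60 cells (Homo sapiens) for antiproliferative activity, read by MTT assay, with a stated time of 72 h (a lower number here means a stronger inhibitor, a higher number a weaker inhibitor), compound 1 gives 1670 nM, the highest number of the three. Compound 2 `NC1=NC2(CCOCC2)N(OCCCOc2cccc(Cl)c2Cl)C(N)=N1` gives 440 nM in this assay, and compound 3 `Cc1cc(C)cc(OCCCON2C(N)=NC(N)=NC23CCOCC3)c1` gives 720 nM. Both departures from the 4-methoxyphenyl group of compound 1 lowered the number beyond the scatter: a 3.8-fold lower number from compound 1 to compound 2 (0.58 log units; beyond the scatter) and a 2.3-fold lower number from compound 1 to compound 3 (0.37 log units; beyond the scatter). Between the two substituted arenes themselves the gap was a 1.6-fold higher number from compound 2 to compound 3 (0.21 log units; within the scatter).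

Compound 4 `NC1=NC2(CCOCC2)N(OCCCOc2ccccc2Br)C(N)=N1` has not yet been measured. It differs from compound 1 in one place: 2-bromophenyl in place of 4-methoxyphenyl on an oxygen on a saturated carbon. The two steps that bear on it are those from compound 1, since each also exchanged the 4-methoxyphenyl for a substituted phenyl without a hydrogen-bond acceptor, and each brought a modest drop. A step of that kind, in the same direction, is expected for compound 4, leaning toward the value of compound 2 because in this assay compound 2 gives 440 nM. Compound 4 is therefore estimated at 600 nM in this assay, with a range from 300 nM to 1200 nM. That estimate corresponds to an expected step of a 2.8-fold lower number from compound 1 to compound 4 (0.44 log units; beyond the scatter).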

Compound 4, half-maximal inhibitory concentration: 610 nM
The estimate for compound 4 lay 1.0-fold (0.01 log units) below the measured number; the range from low to high includes it.
By their numbers in this assay, from the lowest: compounds 2, 4 and 3 (each within the scatter of the next); then compound 1.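

In this assay, 2-bromophenyl joins the other two replacements in lowering the number from the 4-methoxyphenyl of compound 1, with a 2.7-fold lower number from compound 1 to compound 4 (0.44 log units; beyond the scatter), so all three substituted phenyl groups tried at this position stand clear of compound 1, and none of the listed compounds goes against this. The new group cannot be told apart from the earlier two, with a 1.2-fold lower number from compound 3 to compound 4 (0.07 log units; within the scatter) and a 1.4-fold higher number from compound 2 to compound 4 (0.14 log units; within the scatter), so 2-bromophenyl, 2,3-dichlorophenyl and 3,5-dimethylphenyl form a single group of values here, and compound 1 alone stands apart from it. Nothing available here bears on why the 4-methoxyphenyl compound stands apart.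

The compounds shown leave open how an unsubstituted phenyl would compare with these four, and whether a 4-bromophenyl would fall with compound 4 or with compound 1, which would show whether the bromine alone is enough for the step or its place on the ring also counts. They also leave open whether a longer chain in place of the present saturated chain, or a carboxylic acid on the phenyl ring, would keep the number in this range.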